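Methoxy for trifluoromethyl on the piperazine aryl group

The source may report more compounds than this note shows. Statements on the series, on what has been measured and on what is new or still open speak of the compounds shown alone.

Compound 3 `CC(C(=O)NCc1ccc(C(F)(F)F)nc1N1CCN(c2ccc(C(F)(F)F)cc2)CC1)c1ccc(NS(C)(=O)=O)c(F)c1` is tested in a functional assay on CHO-K1 cells for antagonist activity at transient receptor potential cation channel subfamily V member 1 (Homo sapiens), read by FLIPR (on this read-out higher numbers stand for weaker inhibition and lower numbers for stronger inhibition), where it gives 2.3 nM. Compound 2 `Cc1cccc(N2CCN(c3nc(C(F)(F)F)ccc3CNC(=O)C(C)c3ccc(NS(C)(=O)=O)c(F)c3)CC2)c1` gives 3.4 nM, and a 1.5-fold lower number from compound 2 to compound 3 (0.17 log units; within the scatter) stays within the scatter. Compound 1 `CC(C(=O)NCc1ccc(C(F)(F)F)nc1N1CCN(C2CCCCC2)CC1)c1ccc(NS(C)(=O)=O)c(F)c1`, in which a cyclohexyl sits on the amine nitrogen in the ring, gives 21.6 nM; here a 9.4-fold lower number from compound 1 to compound 3 (0.97 log units; beyond the scatter) and a 6.4-fold lower number from compound 1 to compound 2 (0.80 log units; beyond the scatter) are both beyond the scatter.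

Compound 4 `COc1ccc(N2CCN(c3nc(C(F)(F)F)ccc3CNC(=O)C(C)c3ccc(NS(C)(=O)=O)c(F)c3)CC2)cc1` differs from compound 3 by methoxy in place of trifluoromethyl on an aromatic carbon. Going by the values given here, the only measured step that bears on this change is the one between the two aryl groups on the ring nitrogen, a 1.5-fold lower number from compound 2 to compound 3 (0.17 log units; within the scatter), which was within the scatter. Among the compounds with values here, no measured step touches a methoxy group, so the expectation rests on that single aryl-to-aryl comparison, and a step of no more than the scatter in this assay is expected, with no clear direction.

Compound 4 is therefore estimated at 4 nM, within a range from 1.5 nM to 12 nM, which is expected to correspond to a 1.7-fold higher number from compound 3 to compound 4 (0.24 log units; within the scatter).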

Compound 4, inhibition constant: 2.5 nM
Compound 4: the middle estimate sits 1.6-fold (0.20 log units) above what was measured, and the stated range covers the measured number.
By their numbers in this assay, from the lowest: compounds 3, 4 and 2 (each within the scatter of the next); then compound 1.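

In this assay, methoxy in place of trifluoromethyl on the aromatic carbon para to a large group gives a 1.1-fold higher number from compound 3 to compound 4 (0.04 log units; within the scatter) and so shows that this position accepts a group with a hydrogen-bond acceptor in place of one without, with no change that can be told from the scatter. The 4-methoxyphenyl group also cannot be told apart from 3-methylphenyl, with a 1.4-fold lower number from compound 2 to compound 4 (0.13 log units; within the scatter) likewise within the scatter. Set against cyclohexyl, it gives an 8.6-fold lower number from compound 1 to compound 4 (0.94 log units; beyond the scatter) beyond the scatter, so all three aryl groups shown now stand clear of cyclohexyl in this series.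

Going by these compounds, it remains open whether an amine, a carboxylic acid or a longer alkoxy chain at this same position would also leave the number in this range. Nothing available accounts for why methoxy and trifluoromethyl read alike here.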